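Sulfonyl aryl change from compound 2 to compound 3

The source may report more compounds than this note shows. Statements on the series, on what has been measured and on what is new or still open speak of the compounds shown alone.

Measured so far in an ADME assay on microsomes from liver (Mus musculus) for metabolic stability, with a stated time of 10 min (on this read-out higher numbers stand for a more stable compound and lower numbers for a less stable compound), as follows:
- compound 1 `CS(=O)(=O)N1CCC(C(=O)N2CC[C@](c3ccc(C(F)(C(F)(F)F)C(F)(F)F)cc3)(S(=O)(=O)c3ccc(F)cc3)C2)CC1` (69%)
- compound 2 `Cc1ccc(S(=O)(=O)[C@@]2(c3ccc(C(F)(C(F)(F)F)C(F)(F)F)cc3)CCN(C(=O)[C@H]3CC[C@H](C(=O)O)CC3)C2)cc1` (85%)

Compound 2 (85%) holds the higher of the two numbers, and compound 1 (69%) lies lower by more than the usual scatter. Compound 3 `CCc1cc(S(=O)(=O)[C@@]2(c3ccc(C(F)(C(F)(F)F)C(F)(F)F)cc3)CCN(C(=O)[C@H]3CC[C@H](C(=O)O)CC3)C2)ccc1F` is still unmeasured. It carries 3-ethyl-4-fluorophenyl in place of 4-methylphenyl on a sulfonyl sulfur. For the measured compounds named here, no measured pair isolates this change, so the expectation is weakly grounded. In this assay the estimated step of a number 8 percentage points lower from compound 2 to compound 3 (within the scatter) is expected to be a modest fall within the scatter. Compound 3 is estimated at 77% with an expected range of 60% to 90% for now.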

Compound 3, percent of the compound remaining: 73%
Compound 3: the middle estimate sits 4 percentage points above what was measured; the measured number falls inside the stated range.
By their numbers in this assay, from the lowest: compounds 1 and 3 (each within the scatter of the next); then compound 2.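

In this assay, for the compounds shown here, the change from 4-methylphenyl to 3-ethyl-4-fluorophenyl on the sulfonyl sulfur gives a number 12 percentage points lower from compound 2 to compound 3 (beyond the scatter) and is the only one-place reading, so the number responds to this position. The entering group differs from the leaving one in two features, the ethyl and the fluorine, and this pair cannot assign the step to either. Nothing measured here speaks to why the number moves. Open, going by these compounds, is whether the ethyl or the fluorine alone accounts for the step, and whether a methoxy group or an amine in place of the ethyl would keep the number nearer that of compound 2.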